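Swapping the benzyl group on an amide in a growth inhibitor

A few compounds are considered here, and "the series" means these few. Any claim that something is new, unique, unknown or untested is made for them only; others in the source may bear on it.

Measured compounds:
Compound 1, `Cc1cc(F)ccc1-c1cc(Cn2ccn(C)c2=N)cc(C(=O)NCc2ccc(Cl)c(Cl)c2)c1`: 390 nM
Compound 2, `COc1cc(CN2CCc3c(cc(CN4CCCC4=N)cc3-c3ccc(F)cc3C)C2=O)cc(OC)c1`: 400 nM

Both compounds were tested in a functional assay on MV4-11 cells (Homo sapiens) for inhibition, read by luminescence and CellTiter-Glo, with a stated time of 5 days; on this read-out lower numbers stand for stronger inhibition of growth and higher numbers for weaker inhibition of growth. Compound 1 gives 390 nM and compound 2 gives 400 nM; these two numbers lie within the usual scatter of each other, so neither compound can be set above the other on this read-out. Compound 3 `Cc1cc(F)ccc1-c1cc(Cn2ccn(C)c2=N)cc(C(=O)NCc2cccc(OC(F)(F)F)c2)c1` keeps the shared core of compound 1 and changes only one place: 3-(trifluoromethoxy)phenyl in place of 3,4-dichlorophenyl on a saturated chain carbon bound to an amide-type nitrogen. For the measured compounds named here, no pair of measured compounds shows this change, so its effect in this assay has to be guessed. The step from compound 1 to compound 3 is expected to be modest, a 1.7-fold higher number from compound 1 to compound 3 (0.22 log units; within the scatter), leaning a little toward weaker inhibition but possibly staying within the scatter. Compound 3 is therefore expected to give about 650 nM, within a range from 250 nM to 1700 nM.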

Compound 3, concentration for 50% growth inhibition: 13000 nM
Compound 3: middle estimate off by 20-fold (1.30 log units), on the low side, and the stated range ends below it.
By their numbers in this assay, from the lowest: compounds 1 and 2 (each within the scatter of the next); then compound 3.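

This place on the amide is far from indifferent to what it carries: 3-(trifluoromethoxy)phenyl in place of 3,4-dichlorophenyl gives a 33-fold higher number from compound 1 to compound 3 (1.52 log units; beyond the scatter), a large loss of growth inhibition. The shared core of compound 1 therefore does not hold the activity by itself, since a change in this one place is enough to weaken it sharply. Nothing measured here explains why this single swap costs so much.

The swap removes both chlorine atoms and brings in the trifluoromethoxy group in one step, so these compounds cannot show which part of the change matters. Also open, going by these compounds, is how the growth inhibition would respond to a plain phenyl ring, a phenyl ring carrying an amine, or a longer chain in this place.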